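Indole nitrogen substituent: from ethylcarbamoyl to (dimethylcarbamoyl)methyl

The source may report more compounds than this note shows. Statements on the series, on what has been measured and on what is new or still open speak of the compounds shown alone.

Measured so far in a functional assay on the whole organism for inhibition, with Rattus norvegicus as the target; a higher number here means that more compound is needed for the effect, a lower number that less compound is needed:
compound 1 `CN(C)C(=O)n1cc(C(=O)c2ccn3c2CSC3c2cccnc2)c2ccc(Sc3ccc(F)cc3)cc21` gives 0.27 mg/kg
compound 2 `CN(C)C(=O)n1cc(C(=O)c2ccn3c2CSC3c2cccnc2)c2ccc(Oc3ccc(F)cc3)cc21` gives 0.03 mg/kg
compound 3 `CCNC(=O)n1cc(C(=O)c2ccn3c2CSC3c2cccnc2)c2ccc(-c3ccc(F)cc3)cc21` gives 0.18 mg/kg

Compound 3 stands second highest of the three numbers; its value and that of compound 1 lie within the scatter of each other, while compound 2 sits clearly lower. Among the compounds with values here, the only single-point step known is a 9.0-fold lower number from compound 1 to compound 2 (0.95 log units; beyond the scatter), which concerns the group on the aromatic carbon, not the aromatic nitrogen.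

Compound 4 `CN(C)C(=O)Cn1cc(C(=O)c2ccn3c2CSC3c2cccnc2)c2ccc(-c3ccc(F)cc3)cc21` is the next candidate. Its change relative to compound 3 is (dimethylcarbamoyl)methyl in place of ethylcarbamoyl on an aromatic nitrogen. Within the data shown here, no measured pair isolates this position: compound 1 and compound 3 differ there, but also at the aromatic carbon, and their two values are within the scatter, so nothing can be read from them about the nitrogen substituent alone. Among the measured compounds shown here, with no relevant step, the expectation for compound 4 is a value near that of compound 3, with a wide range: it is estimated at 0.2 mg/kg (0.05 mg/kg to 0.8 mg/kg), a step of a 1.1-fold higher number from compound 3 to compound 4 (0.05 log units; within the scatter) in this assay, not expected to go beyond the scatter in either direction.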

Compound 4, dose for half-maximal effect: 0.009 mg/kg
Beside the measured number, compound 4's estimate is 22-fold (1.35 log units) above it; the whole stated range lies above it.
By their numbers in this assay, from the lowest: compound 4; then compound 2; then compounds 3 and 1 (each within the scatter of the next).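

This position is a strong lever in this assay: the step with only the group on the aromatic nitrogen changed is a 20-fold lower number from compound 3 to compound 4 (1.30 log units; beyond the scatter), and it lies beyond the scatter. The earlier compounds shown here could not show this, since compound 1 and compound 3 differ in two places. The change replaces ethylcarbamoyl, with 1 hydrogen-bond donor, by (dimethylcarbamoyl)methyl, with 0 donors, and no measurement available accounts for the step.

The compounds shown do not separate the loss of the amide hydrogen from the insertion of the methylene, which (ethylcarbamoyl)methyl on the same nitrogen would address. Also open, as far as these compounds go, are whether a carboxylic acid or a longer chain at this position would hold the low dose, and whether the step carries over to the 4-fluorophenoxy series.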